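Inverting the ring stereocentre of compound 1

The source may report more compounds than this note shows. Statements on the series, on what has been measured and on what is new or still open speak of the compounds shown alone.

In a functional assay on RAW264.7 cells (Mus musculus) for inhibition, with a stated time of 30 min (on this read-out higher numbers stand for weaker inhibition and lower numbers for stronger inhibition), compound 1 (`C=C1C(=O)OC[C@@H]1CCOC(=O)Nc1cc(C)cc(C)c1`) gives 1240 nM as the highest of the three numbers, which makes it the weakest inhibitor measured so far. Compound 2 (`C=C1C(=O)OC[C@H]1CCOC(=O)Nc1cccc(Br)c1`) gives 590 nM as its number, and compound 3 (`C=C1C(=O)OC[C@H]1CCOC(=O)Nc1ccc(C(=O)OCCCC)cc1`) gives 430 nM as its number. Both lie lower than compound 1 by more than the usual scatter.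

Compound 4 (`C=C1C(=O)OC[C@H]1CCOC(=O)Nc1cc(C)cc(C)c1`) has the same atoms and bonds as compound 1. For the measured compounds named here, the only change is the two compounds have the same atoms and bonds and differ only in configuration as drawn: 1 of 1 stereo elements differ; a stereocentre at a saturated ring carbon is drawn R in compound 1 and S in compound 4 in configuration: a stereocentre at a saturated ring carbon is drawn R in compound 1 and S in compound 4. Going by the values given here, compound 2 and compound 3 are drawn with the configuration of compound 4 but carry other substituents, so no measured pair isolates this change.

The expected change is a modest one toward stronger inhibition, a 1.8-fold lower number from compound 1 to compound 4 (0.25 log units; within the scatter) as the estimated step, close in size to the scatter. For compound 4 the estimated value is 700 nM with 300 nM to 1600 nM as the expected range.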

Compound 4, half-maximal inhibitory concentration: 480 nM
Compound 4: middle estimate off by 1.5-fold (0.16 log units), on the high side; measured number inside the range.
By their numbers in this assay, from the lowest: compounds 3, 4 and 2 (each within the scatter of the next); then compound 1.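

For the compounds shown here, compounds 1 and 4 form the first matched pair, and in this assay they show that the ring stereocentre alone shifts the read-out: a 2.6-fold lower number from compound 1 to compound 4 (0.41 log units; beyond the scatter). Compound 2 and compound 3 share the S drawing but carry other substituents, so neither gave a reading of this centre on its own. The step can be assigned to configuration because nothing else separates the pair: the fact that compounds 1 and 4 differ only in the configuration as drawn.

Still open is whether a step of this size carries over to the substituents of compound 2 and compound 3, where only the S drawing is shown. Also open, going by these compounds, is how the S configuration behaves with an amine or a carboxylic acid in place of the methyl groups of compound 4.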